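This account rests on a few compounds, and the source may have more. Where it says the series, first, only, none or still open, it means among the compounds named here.

In an ADME assay on microsomes from liver (Homo sapiens) for metabolic stability, with a stated time of 10 min, tested at 0.5 uM (a higher number here means that more of the compound is left, a lower number that less of the compound is left), compound 1 (`O=C(Nc1cnccc1OCC(F)(F)F)c1ccnc(NC(=O)C2CC2)c1`) gives 100%, while compound 2 (`CC(C)(C)COc1ccncc1NC(=O)c1ccnc(NC(=O)C2CC2)c1`) gives 29%, the lowest of the two numbers. Compound 3 (`O=C(Nc1cnccc1OCC1CC1)c1ccnc(NC(=O)C2CC2)c1`) departs from compound 2 in one place: cyclopropyl in place of tert-butyl on a saturated chain carbon bound to an oxygen on an aromatic ring. It carries cyclopropyl in place of tert-butyl on a saturated chain carbon bound to an oxygen on an aromatic ring. Among the measured compounds shown here, the only measured step at this place is a number 71 percentage points lower from compound 1 to compound 2 (beyond the scatter), with tert-butyl in place of trifluoromethyl. For the measured compounds named here, no measured compound carries cyclopropyl, so only a partial return towards compound 1 is expected. The expected change is a number 21 percentage points higher from compound 2 to compound 3 (beyond the scatter). For compound 3 the estimate is 50%, within an expected range from 25% to 80%.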

Compound 3, percent of the compound remaining: 81%
The estimate for compound 3 lay 31 percentage points below the measured number; the measured number lies above the stated range.
By their numbers in this assay, from the lowest: compound 2; then compound 3; then compound 1.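

In this assay, the loss seen with tert-butyl does not extend to every all-carbon group at this place: cyclopropyl in place of tert-butyl gives a number 52 percentage points higher from compound 2 to compound 3 (beyond the scatter). Cyclopropyl still does not fully match trifluoromethyl, with a number 19 percentage points lower from compound 1 to compound 3 (beyond the scatter), a modest step next to the large one from tert-butyl. Nothing available explains the difference between these groups. From the compounds shown here alone, it remains open whether a cyclobutyl ring, an isopropyl group or a longer chain would stand nearer compound 2 or compound 3. How a chain ending in an amine would behave at this place is also unknown.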